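Substituent at the saturated ring carbon: estimate for compound 4

The source may report more compounds than this note shows. Statements on the series, on what has been measured and on what is new or still open speak of the compounds shown alone.

Measured so far:
compound 1 `Cc1cc(O)c(C2=NN(c3ccc(S(N)(=O)=O)cc3)C(c3ccccc3O)C2)cc1Cl`: 3520 nM
compound 2 `Cc1cc(O)c(C2=NN(c3ccc(S(N)(=O)=O)cc3)C(c3ccccc3Cl)C2)cc1Cl`: 3320 nM
compound 3 `Cc1cc(O)c(C2=NN(c3ccc(S(N)(=O)=O)cc3)C(/C=C/c3ccccc3)C2)cc1Cl`: 11500 nM

All values come from a functional assay on PC-3 cells (Homo sapiens) for antiproliferative activity, with a stated time of 48 h; a higher number here means a weaker inhibitor of growth, a lower number a stronger inhibitor of growth. Compound 3 gives the highest number of the three: a 3.3-fold higher number from compound 1 to compound 3 (0.51 log units; beyond the scatter) and a 3.5-fold higher number from compound 2 to compound 3 (0.54 log units; beyond the scatter), whereas a 1.1-fold lower number from compound 1 to compound 2 (0.03 log units; within the scatter). Compound 4 `COc1ccc(C2CC(c3cc(Cl)c(C)cc3O)=NN2c2ccc(S(N)(=O)=O)cc2)cc1OC` differs from compound 3 by 3,4-dimethoxyphenyl in place of 2-phenylethenyl on a saturated ring carbon. The steps from compound 1 and from compound 2 to compound 3 bear on this change; both were modest rises on going from an aryl group at that carbon to 2-phenylethenyl. Among the measured compounds shown here, compound 4 returns an aryl group to that carbon, so a drop of about that size is expected in this assay; no measured compound carries 3,4-dimethoxyphenyl, which leaves the size uncertain. Compound 4 is therefore estimated at 4000 nM (range 1500 nM to 12000 nM), which is a 2.9-fold lower number from compound 3 to compound 4 (0.46 log units; beyond the scatter).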

Compound 4, concentration for total growth inhibition: 13700 nM
Compound 4: the middle estimate sits 3.4-fold (0.53 log units) below what was measured, and the stated range ends below it.
By their numbers in this assay, from the lowest: compounds 2 and 1 (each within the scatter of the next); then compounds 3 and 4 (each within the scatter of the next).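

In this assay, an aryl group at the saturated ring carbon does not by itself bring the number down: 3,4-dimethoxyphenyl in place of 2-phenylethenyl gives a 1.2-fold higher number from compound 3 to compound 4 (0.08 log units; within the scatter). Against the 2-chlorophenyl and 2-hydroxyphenyl groups, the same group gives a 4.1-fold higher number from compound 2 to compound 4 (0.62 log units; beyond the scatter) and a 3.9-fold higher number from compound 1 to compound 4 (0.59 log units; beyond the scatter), so the outcome at this position depends on the aryl group's substituents, not only on the presence of an aryl group. Nothing available accounts for this difference.

From the compounds shown here alone, it remains open whether the rise tracks both methoxy groups or only one. Plain phenyl and 3-aminophenyl at this carbon would help separate these cases.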